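Swapping Phenyl for an Anilide Arm on the Ring Nitrogen

A few compounds are considered here, and "the series" means these few. Any claim that something is new, unique, unknown or untested is made for them only; others in the source may bear on it.

Compound 2 `CCOC(=O)C1=Cc2ccccc2OC1(OCc1cn(-c2ccccc2)nn1)C(F)(F)F` carries a phenyl group on an aromatic nitrogen of the shared core. In a functional assay on A549 cells (Homo sapiens) for inhibition, read by MTT assay, with a stated time of 24 h (on this read-out lower numbers stand for stronger inhibition and higher numbers for weaker inhibition), compound 2 gives only a limit of the assay, > 150000 nM, so no number is known for it. Compound 3 `CCOC(=O)C1=Cc2ccccc2OC1(OCc1cn(CC(=O)Nc2ccccc2Br)nn1)C(F)(F)F` differs from compound 2 in one place: ((2-bromophenyl)carbamoyl)methyl in place of phenyl on an aromatic nitrogen. Within the data shown here, one measured step bears on this change, and it runs the other way. Compound 1 `CCOC(=O)C1=Cc2ccccc2OC1(OCc1cn(CC(=O)Nc2cccc(Cl)c2)nn1)C(F)(F)F` carries ((3-chlorophenyl)carbamoyl)methyl on that nitrogen, and in this assay compound 1 gives 12800 nM. The step of an at least 11-fold higher number from compound 1 to compound 2 (1.06 log units; beyond the scatter) shows that exchanging that arm for plain phenyl weakened inhibition strongly. Compound 2 sits at the limit of > 150000 nM in this assay, at which 1 of the 2 values shown sits. Compound 3 reverses that exchange, with a 2-bromophenyl in place of the 3-chlorophenyl in the arm, so its entering group resembles the arm of compound 1. A large step back toward stronger inhibition is therefore expected for compound 3, an at least 10-fold lower number from compound 2 to compound 3 (1.00 log units; beyond the scatter). The estimated value for compound 3 in this assay is 15000 nM, with a range from 5000 nM to 60000 nM.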

Compound 3, half-maximal inhibitory concentration: > 150000 nM
Compound 3: only a limit was reported; the forecaster's own chance of this, stated with the estimate: 20%; at least 10-fold (1.00 log units) between middle value and limit.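

In this assay, the anilide arm on the ring nitrogen turns out not to secure inhibition by itself: 2-bromophenyl in place of 3-chlorophenyl on the amide-type nitrogen gives an at least 11-fold higher number from compound 1 to compound 3 (1.06 log units; beyond the scatter). This is a large loss from a change within the arm, whereas the earlier step compared the whole arm with plain phenyl. Compound 2 and compound 3 both rest at a limit of the assay, so the step between them cannot be read, and neither can be ranked against the other: the limit of > 150000 nM in this assay, at which 2 of the 3 values shown sit.

The change from compound 1 to compound 3 alters both the halogen and the place it occupies on the phenyl ring, and the compounds shown cannot separate these two effects; a 3-bromophenyl or 2-chlorophenyl arm would be needed to tell them apart. Also open, on these data alone, is how the arm would read with an unsubstituted phenyl ring, or with a methoxy group or a carboxylic acid on that ring.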